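From Chloro to Methoxy on Compound 1

The compounds below may be only part of what the source reports. "The series", "measured", "known", "first", "only" and "open" are said of these compounds alone.

Among the compounds with values here, in a functional assay on HCT-116 cells (Homo sapiens) for inhibition, read by MTT assay, with a stated time of 2 days (on this read-out lower numbers stand for stronger inhibition of growth and higher numbers for weaker inhibition of growth), compound 1 (`Nc1ccccc1NC(=O)CCCNCC(=O)Nc1ccc(Cl)cc1`) gives 5500 nM and holds the higher of the two numbers so far. Compound 2 (`Nc1ccccc1NC(=O)c1ccc(NCC(=O)Nc2ccc([N+](=O)[O-])cc2)cc1`) gives 600 nM in this assay and sits lower by more than the scatter, but it differs from compound 1 in more than one place. Compound 3 (`COc1ccc(NC(=O)CNCCCC(=O)Nc2ccccc2N)cc1`) is still unmeasured. It carries methoxy in place of chloro on an aromatic carbon of compound 1, para to a large group (methoxy in place of chloro on an aromatic carbon) and nothing else changes. Within the data shown here, no measured pair isolates this change. The expectation therefore starts from compound 1 at 5500 nM and foresees no step beyond the scatter in this assay, in either direction. The expected step runs a 1.1-fold higher number from compound 1 to compound 3 (0.04 log units; within the scatter) as an estimate only. For compound 3 the estimated value is 6000 nM with an expected range from 2500 nM to 14000 nM in this measurement.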

Compound 3, concentration for 50% growth inhibition: 8600 nM
Estimate against measurement, compound 3: 1.4-fold (0.16 log units) below; low and high end bracket the measured number.
By their numbers in this assay, from the lowest: compound 2; then compounds 1 and 3 (each within the scatter of the next).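

Within the data shown here, this pair is the first in which a single change can be read on its own: in this assay, methoxy in place of chloro on an aromatic carbon, para to a large group, gives a 1.6-fold higher number from compound 1 to compound 3 (0.19 log units; within the scatter), so the two compounds cannot be told apart in this read-out. At this position, then, the move from 4-chlorophenyl to 4-methoxyphenyl, which brings one more heavy atom and a hydrogen-bond acceptor, leaves the growth-inhibition number within what repeated measurements would scatter. Nothing on hand bears on why the two numbers stay together.

Going by these compounds, whether a different group at this position, such as an amine or a carboxylic acid, would step beyond the scatter remains open. So does whether methoxy in place of chloro would read the same on another core, such as that of compound 2.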